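A few compounds are considered here, and "the series" means these few. Any claim that something is new, unique, unknown or untested is made for them only; others in the source may bear on it.

Going by the values given here, in a functional assay on HeLa cells (Homo sapiens) for antiproliferative activity, with a stated time of 24 h (a higher number here means a weaker inhibitor, a lower number a stronger inhibitor), compound 2, `NC(=O)c1c(NC(=O)c2ccccc2Cl)sc2c1CCN(C(=S)Nc1ccccc1)C2`, gives 46700 nM, the only number reported. Compound 1, `N#Cc1ccccc1CN1CCc2c(sc(NC(=O)c3ccccc3Cl)c2C(N)=O)C1`, is recorded in this assay only as > 50000 nM. For compound 1 that value is a limit, (the limit of > 50000 nM in this assay, at which 1 of the 2 values shown sits). The step of an at least 1.0-fold lower number from compound 1 to compound 2 (0.02 log units; that floor lies within the scatter) exchanged the group on the ring amine nitrogen. Compound 3, `NC(=O)c1c(NC(=O)c2ccccc2Cl)sc2c1CCN(C(=O)Nc1ccccc1Cl)C2`, changes the same position again: a group of 10 heavy atoms (7 carbon, 1 nitrogen, 1 oxygen, 1 chlorine; one six-membered aromatic ring of carbon only) in place of a group of 9 heavy atoms (7 carbon, 1 nitrogen, 1 sulfur; one six-membered aromatic ring of carbon only), on an amine nitrogen in a ring. Among the compounds with values here, only that one measured step bears on this, and it lies within the scatter, so no shift beyond the scatter is expected. Compound 3 is expected to give 45000 nM, between 15000 nM and 150000 nM. This amounts to an estimated step of a 1.0-fold lower number from compound 2 to compound 3 (0.02 log units; within the scatter).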

Compound 3, half-maximal inhibitory concentration: 45400 nM
Beside the measured number, compound 3's estimate is 1.0-fold (0.00 log units) below it; the range from low to high includes it.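

In this assay, placing (2-chlorophenyl)carbamoyl on the amine nitrogen in a ring gives a 1.0-fold lower number from compound 2 to compound 3 (0.01 log units; within the scatter), so compound 2 and compound 3 cannot be told apart, and this change of group shows no effect beyond the scatter. Against 2-cyanobenzyl at the same place, the record is an at least 1.1-fold lower number from compound 1 to compound 3 (0.04 log units; that floor lies within the scatter). That step gives only a floor, since the entry for compound 1 is a limit: the limit of > 50000 nM in this assay, at which 1 of the 3 values shown sits.

On these data alone, whether a basic amine, a carboxylic acid or a longer alkyl chain on this nitrogen would give a number beyond the scatter stays open.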